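This account rests on a few compounds, and the source may have more. Where it says the series, first, only, none or still open, it means among the compounds named here.

Working notes on the series.

The series rests on a shared core carrying a saturated ring that links a bicyclic aromatic part to a side chain bearing the heteroaromatic group. Compound 1 `CCC(Nc1nnc(-c2ccc(OC)cc2)o1)[C@H]1CC[C@@H](c2ccnc3ccc(F)cc32)CC1` is the reference point: in an assay on tissue (M109 cells) for inhibition of Indoleamine 2,3-dioxygenase 1 (Mus musculus), read by fluorescence, with a stated time of 18 h (on this read-out lower numbers stand for stronger inhibition and higher numbers for weaker inhibition), compound 1 gives 31 nM. Within the data shown here, compound 3 `CCC(Nc1nnc(-c2ccc(OC)cc2)o1)[C@H]1CC[C@@H](c2ccnc3c(F)cc(F)cc32)CC1` gives 36 nM; the step of a 1.2-fold higher number from compound 1 to compound 3 (0.06 log units; within the scatter) is the only single-point change measured so far. Compound 2 `CCC(c1nc2ncc(Cl)cc2[nH]1)[C@H]1CC[C@@H](c2ccnc3ccc(C(F)(F)F)cc32)CC1`, with a different core and a trifluoromethyl group, gives 3 nM, the lowest of the three numbers, and its gap to compound 1 lies beyond the scatter; compound 1 thus stands second highest of the three.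

Compound 4 `COCC(Nc1nnc(-c2ccc(OC)cc2)o1)[C@H]1CC[C@@H](c2ccnc3ccc(F)cc32)CC1` differs from compound 1 in one place: methoxy in place of methyl on a saturated chain carbon, two bonds along the chain from a nitrogen on an aromatic ring and a saturated ring carbon. Among the measured compounds shown here, no measured step bears on this kind of change; the single step from compound 1 to compound 3 concerns an aromatic fluoro and was within the scatter, so it gives no guidance on a chain change. With nothing to set a direction, the expectation for compound 4 is a step of a 1.3-fold higher number from compound 1 to compound 4 (0.11 log units; within the scatter) of no more than the usual scatter, in either direction. Compound 4 is accordingly estimated at 40 nM, with a range from 12 nM to 130 nM.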

Compound 4, half-maximal inhibitory concentration: 44 nM
Beside the measured number, compound 4's estimate is 1.1-fold (0.04 log units) below it; measured number inside the range.
By their numbers in this assay, from the lowest: compound 2; then compounds 1, 3 and 4 (each within the scatter of the next).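

In this assay, among these compounds, a 1.4-fold higher number from compound 1 to compound 4 (0.15 log units; within the scatter) is the only measured step at this position, and it shows that methoxy in place of methyl on this saturated chain carbon, which reads as ethyl to methoxymethyl when cut one bond further out, leaves the number within the scatter. The earlier step, a 1.2-fold higher number from compound 1 to compound 3 (0.06 log units; within the scatter), concerned only an aromatic fluoro, so the series now holds one change on the chain and one on the aromatic part of the core of compound 1, neither of them beyond the scatter. The data at hand offer no measurement that would account for this outcome.

On these data alone, one replacement does not show how much change this chain carbon accepts, so it remains open whether an amine, a carboxylic acid or a longer chain in the same place would also stay within the scatter of compound 1. As far as these compounds go, it also remains open whether methoxy in place of methyl would give a similarly small step on the different core of compound 2.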